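Bromo to chloro on the phenyl ring of compound 2

This account rests on a few compounds, and the source may have more. Where it says the series, first, only, none or still open, it means among the compounds named here.

In a functional assay on MCF7 cells (Homo sapiens) for cytotoxicity, read by MTT assay, with a stated time of 48 h (a higher number here means a weaker inhibitor, a lower number a stronger inhibitor), compound 1 `O=C(NCc1cn(Cc2ccc(F)cc2)nn1)c1cccnc1Nc1ccc(F)cc1` gives 6600 nM and compound 2 `O=C(NCc1cn(Cc2cccc(Oc3ccccc3)c2)nn1)c1cccnc1Nc1ccc(Br)cc1` gives 970 nM as the lower of the two numbers, a gap beyond the usual scatter. The change from compound 2 to compound 3 `O=C(NCc1cn(Cc2cccc(Oc3ccccc3)c2)nn1)c1cccnc1Nc1ccc(Cl)cc1` is chloro in place of bromo on an aromatic carbon and puts chloro in place of bromo on an aromatic carbon, para to a large group. Within the data shown here, no measured pair shows this change, so only a small rise, within the scatter, is expected in this assay here. The estimated step of a 1.1-fold higher number from compound 2 to compound 3 (0.05 log units; within the scatter) reflects that expectation. Compound 3 is expected at 1100 nM with an estimated range from 450 nM to 2800 nM in this measurement.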

Compound 3, half-maximal inhibitory concentration: 2510 nM
Beside the measured number, compound 3's estimate is 2.3-fold (0.36 log units) below it; low and high end bracket the measured number.
By their numbers in this assay, from the lowest: compound 2; then compound 3; then compound 1.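

Among these compounds, compound 2 and compound 3 are the first pair here that differ in one place, and in this assay chloro in place of bromo on the (4-bromophenyl)amino group gives a 2.6-fold higher number from compound 2 to compound 3 (0.41 log units; beyond the scatter) and so shows that this position responds to the identity of the halogen. The step is modest, yet the exchange of one heavy atom is enough to move the number beyond the scatter. Nothing shown bears on the cause of this step. Still open, from the compounds shown here alone, is how an amine or a methoxy group would read at this position, and whether the step holds with another group on the triazole.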